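The compounds below may be only part of what the source reports. "The series", "measured", "known", "first", "only" and "open" are said of these compounds alone.

Three sulfonamides built on the shared core of compound 1 `Cc1ccc(S(=O)(=O)Nc2ccc3oc(-c4ccccc4)nc3c2)cc1` have been tested in an assay on cells for inhibition of HSP60/HSP10 (Homo sapiens), with a stated time of 60 min; a lower number here means a stronger inhibitor, a higher number a weaker inhibitor. Compound 1 gives > 100000 nM, which is a limit of the assay rather than a number. Compound 2 `Cc1ccccc1S(=O)(=O)Nc1ccc2oc(-c3ccccc3)nc2c1` likewise gives > 100000 nM, again only a limit. Compound 3 `COc1cccc(S(=O)(=O)Nc2ccc3oc(-c4ccccc4)nc3c2)c1` gives > 100000 nM, also a limit. Because all three values sit at the limit of > 100000 nM in this assay, at which 3 of the 3 values shown sit, the three steps among them, a step that the two limits leave unreadable from compound 1 to compound 2, a step that the two limits leave unreadable from compound 1 to compound 3 and a step that the two limits leave unreadable from compound 2 to compound 3, cannot be read in either size or direction; they show only that changing the substituent on the phenyl attached to the sulfonyl sulfur between a methyl in two positions and a methoxy left every compound at the same limit.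

Compound 4 `O=S(=O)(Nc1ccc2oc(-c3ccccc3)nc2c1)c1ccccc1C(F)(F)F` differs from compound 2 in one place: trifluoromethyl in place of methyl on an aromatic carbon. Within the data shown here, no measured step reports on a trifluoromethyl here, and the three measured compounds give no readable step at all. With compound 2 at a limit, the step of a number no higher from compound 2 to compound 4 (the limit leaves the size open) is expected to be no more than a small one, most likely leaving compound 4 at the same limit. Compound 4 is therefore estimated at 100000 nM, with a range from 30000 nM to 300000 nM.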

Compound 4, half-maximal inhibitory concentration: > 100000 nM
Compound 4: no number, only a limit (the forecaster's own chance of this, stated with the estimate: 80%); the middle value sits exactly at the limit.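

In this assay compound 4 gives > 100000 nM, which is a limit and not a number. The step from compound 2 to compound 4 cannot be read in size or direction, because both compounds stand at the same limit: the limit of > 100000 nM in this assay, at which 4 of the 4 values shown sit.

The compounds shown leave open how strongly any of them inhibits, and which change to the shared core, if any, would give a readable number.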